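Replacing a Propyl Terminus with Dibutylamino: Compound 3

The source may report more compounds than this note shows. Statements on the series, on what has been measured and on what is new or still open speak of the compounds shown alone.

Compound 1 `CCCCCCCOc1c(-c2cc(OC)c(OC)c(OC)c2)oc2ccccc2c1=O` is tested in a functional assay on PC-3 cells (Homo sapiens) for antiproliferative activity, read by WST assay, with a stated time of 3 days (on this read-out higher numbers stand for weaker inhibition and lower numbers for stronger inhibition), where compound 1 gives only a limit of the assay, > 50000 nM. Its close relative compound 2 `CCCC(C)Oc1c(-c2cc(OC)c(OC)c(OC)c2)oc2ccccc2c1=O`, carrying 1-methylbutyl in place of heptyl on an oxygen on an aromatic ring, gives 49300 nM in this assay. The step of an at least 1.0-fold lower number from compound 1 to compound 2 (0.00 log units; that floor lies within the scatter) shows no movement beyond the scatter, and compound 1 sits at the limit of > 50000 nM in this assay, at which 1 of the 2 values shown sits. Compound 3 `CCCCN(CCCC)CCCCOc1c(-c2cc(OC)c(OC)c(OC)c2)oc2ccccc2c1=O` differs from compound 1 by dibutylamino in place of propyl on a saturated chain carbon, four bonds along the chain from an oxygen on an aromatic ring. For the measured compounds named here, the one measured step, from compound 1 to compound 2, changed only the branching of the chain and stayed within the scatter; no measured pair brings in a nitrogen, so the numbers give no direction for this change. The expected step in this assay is an at least 1.6-fold lower number from compound 1 to compound 3 (0.22 log units; that floor lies within the scatter), a modest drop that may still not clear the scatter. Compound 3 is therefore estimated at 30000 nM, within 8000 nM to 100000 nM.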

Compound 3, half-maximal inhibitory concentration: 5300 nM
Estimate against measurement, compound 3: 5.7-fold (0.75 log units) above; measured number below the stated range.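

In this assay, a saturated chain carbon four bonds along the chain from an oxygen on an aromatic ring proves to be a place where a change moves the number: dibutylamino in place of propyl gives an at least 9.4-fold lower number from compound 1 to compound 3 (0.97 log units; beyond the scatter). For the compounds shown here, the earlier step, an at least 1.0-fold lower number from compound 1 to compound 2 (0.00 log units; that floor lies within the scatter), changed only the alkyl group on that oxygen, so compound 3 is the first here with a nitrogen in the chain and the first whose step clears the scatter. Compound 1 stands at a limit of the assay, so the step is only a floor: the limit of > 50000 nM in this assay, at which 1 of the 3 values shown sits.

Going by these compounds, it remains open whether the step follows the nitrogen or the larger group. Also open, on these data alone, is whether a smaller amine such as dimethylamino, or a carboxylic acid on the same chain carbon, would give a comparable number in this assay.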